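A few compounds are considered here, and "the series" means these few. Any claim that something is new, unique, unknown or untested is made for them only; others in the source may bear on it.

Three compounds were tested in an ADME assay on L6 cells (Rattus norvegicus) for cytotoxicity, read by resazurin assay, with a stated time of 72 h; on this read-out higher numbers stand for weaker inhibition and lower numbers for stronger inhibition. Compound 1 `CN1CCN(CC(=O)NC2CC3(N(C)C)CC(c4ccccc4)C2C(c2ccccc2)C3)CC1` gives 66200 nM, compound 2 `O=C(CN1CCCCC1)OC1CC2(N3CCCCC3)CC(c3ccccc3)C1C(c1ccccc1)C2` gives 60400 nM, and compound 3 `CN(C)C12CC(OC(=O)CN3CCCCC3)C(C(c3ccccc3)C1)C(c1ccccc1)C2` gives 29300 nM. The change (((4-methylpiperazin-1-yl)methyl)carbonyl)amino in place of (((piperidin-1-yl)methyl)carbonyl)oxy on a saturated ring carbon produced a 2.3-fold higher number from compound 3 to compound 1 (0.35 log units; beyond the scatter). The cores of compound 2 and compound 3 differ by piperidin-1-yl in place of dimethylamino on a saturated ring carbon, which gave a 2.1-fold lower number from compound 2 to compound 3 (0.31 log units; beyond the scatter).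

Compound 4 `CN1CCN(CC(=O)NC2CC3(N4CCCCC4)CC(c4ccccc4)C2C(c2ccccc2)C3)CC1` is not yet measured. It differs from compound 2 by (((4-methylpiperazin-1-yl)methyl)carbonyl)amino in place of (((piperidin-1-yl)methyl)carbonyl)oxy on a saturated ring carbon. This is the same kind of change as from compound 3 to compound 1, but not the same: in compound 2 the place is two ring bonds from the ring atom that bears a piperidin-1-yl group, whereas in compound 3 it is two ring bonds from the ring atom that bears a dimethylamino group. Because a 2.3-fold higher number from compound 3 to compound 1 (0.35 log units; beyond the scatter) was seen once on the other core, the step from compound 2 to compound 4 is expected to be a 2.2-fold higher number from compound 2 to compound 4 (0.33 log units; beyond the scatter). Compound 4 is thus estimated at 130000 nM, between 60000 nM and 300000 nM.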

Compound 4, half-maximal inhibitory concentration: 57500 nM
Compound 4: middle estimate off by 2.3-fold (0.35 log units), on the high side, outside the stated range (below it).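

In this assay, (((4-methylpiperazin-1-yl)methyl)carbonyl)amino in place of (((piperidin-1-yl)methyl)carbonyl)oxy gave a 1.1-fold lower number from compound 2 to compound 4 (0.02 log units; within the scatter), and the two results for this change agree as far as the scatter allows: the same change on two cores in this assay, a 2.3-fold higher number (0.35 log units; beyond the scatter) from compound 3 to compound 1 and a 1.1-fold lower number (0.02 log units; within the scatter) from compound 2 to compound 4, 2.4-fold (0.38 log units) apart, within the scatter of two such steps. Likewise, piperidin-1-yl in place of dimethylamino gave a 1.2-fold lower number from compound 1 to compound 4 (0.06 log units; within the scatter), and these two results also agree as far as the scatter allows: the same change on two cores in this assay, a 2.1-fold lower number (0.31 log units; beyond the scatter) from compound 2 to compound 3 and a 1.2-fold higher number (0.06 log units; within the scatter) from compound 4 to compound 1, 2.4-fold (0.38 log units) apart, within the scatter of two such steps. Neither change can therefore be said to behave differently on the two cores, but two results per change do not prove that either carries over unchanged or fix the size of its step.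

The compounds shown leave open how a morpholine ring or a primary amine would read in place of the dimethylamino group. They also leave open what a longer chain in the amide side chain would do.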